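A few compounds are considered here, and "the series" means these few. Any claim that something is new, unique, unknown or untested is made for them only; others in the source may bear on it.

In a functional assay on the whole organism (blood) with Rattus norvegicus as the target, with stated times of 24 h and 1 h, at a dose of 15 mg/kg by the intraperitoneal route (on this read-out lower numbers stand for a weaker effect and higher numbers for a stronger effect at the one dose given), compound 2 `O=C(NC[C@@H]1C[C@@H]2C=C[C@@H]1C2)NS(=O)(=O)N1CCC(CCNC(=O)c2cscn2)CC1` gives 37%, the higher of the two numbers shown; compound 1 `O=C(NC[C@@H]1C[C@@H]2C=C[C@@H]1C2)NS(=O)(=O)N1CCC(CCNC(=O)c2cnsc2)CC1` gives 14%. Compound 3 `O=C(NC[C@@H]1C[C@@H]2C=C[C@@H]1C2)NS(=O)(=O)N1CCC(CCNC(=O)c2cc(Cl)ccn2)CC1` has not yet been measured. It differs from compound 2 in one place: 4-chloropyridin-2-yl in place of 1,3-thiazol-4-yl on a carbonyl carbon. Among the measured compounds shown here, the only measured step, a number 23 percentage points higher from compound 1 to compound 2 (beyond the scatter), also exchanged one ring for another on the same carbonyl carbon, so a change here can move the read-out modestly; yet no measured step involves a six-membered ring, so the direction is open. The step expected is a number 4 percentage points lower from compound 2 to compound 3 (within the scatter), small. Compound 3 is estimated at 33%, within 12% to 58%.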

Compound 3, a percentage reported as activity, at one dose (the size of the read-out at that dose, not a potency): 46%
For compound 3 the middle estimate is 13 percentage points below the measured one; measured number inside the range.
By their numbers in this assay, from the lowest: compound 1; then compounds 2 and 3 (each within the scatter of the next).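

In this assay a six-membered aromatic ring is accepted on this carbonyl carbon: 4-chloropyridin-2-yl in place of 1,3-thiazol-4-yl leaves the read-out close (a number 9 percentage points higher from compound 2 to compound 3 (within the scatter)). In place of 1,2-thiazol-4-yl the same ring gives a clear gain (a number 32 percentage points higher from compound 1 to compound 3 (beyond the scatter)), so among these three rings only compound 1 stands apart, and ring size alone does not set the read-out. No measurement here offers an explanation.

From the compounds shown here alone, what the chlorine contributes stays open. So does the outcome with a plain pyridin-2-yl or a phenyl ring on the same carbonyl carbon.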